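This account rests on a few compounds, and the source may have more. Where it says the series, first, only, none or still open, it means among the compounds named here.

Within the data shown here, compound 2 `Cc1nn(-c2nc(-c3ccc(Cl)c(Cl)c3)c(SC(C)C)s2)c(C(=O)O)c1-c1cccc(C(F)(F)F)c1` is, in a functional assay on BJAB cells (Homo sapiens) for antiproliferative activity, with a stated time of 4 days (a lower number here means that less compound is needed, a higher number that more compound is needed for the effect), the compound with the higher of the two numbers known: compound 2 gives 22000 nM, whereas compound 1 `COc1cc(-c2c(C)nn(-c3nc(-c4ccc(Cl)c(Cl)c4)c(SC(C)C)s3)c2C(=O)O)cc(C(F)(F)F)c1` gives 1380 nM. Among the measured compounds shown here, the one step measured, a 16-fold higher number from compound 1 to compound 2 (1.20 log units; beyond the scatter), concerns hydrogen in place of methoxy on an aromatic carbon and is the only comparison available. Compound 3 `Cc1nn(-c2nc(-c3ccc(Cl)c(Cl)c3)c(SC(C)C)s2)c(C(=O)O)c1-c1cccc(F)c1` differs from compound 2 as follows: fluoro in place of trifluoromethyl on an aromatic carbon. For the measured compounds named here, no measured step touches the trifluoromethyl-bearing ring, so the measured step gives no direct guidance on this change, and the expectation rests on the change being confined to that ring. Compound 3 is therefore expected to lie close to compound 2 in this assay, with a step of no change at the digits printed from compound 2 to compound 3 (within the scatter) that is not expected to go beyond the scatter. The estimate for compound 3 is 22000 nM, within a range from 5000 nM to 70000 nM.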

Compound 3, half-maximal effective concentration: 900 nM
The estimate for compound 3 lay 24-fold (1.39 log units) above the measured number; the whole stated range lies above it.
By their numbers in this assay, from the lowest: compounds 3 and 1 (each within the scatter of the next); then compound 2.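

In this assay, a 24-fold lower number from compound 2 to compound 3 (1.39 log units; beyond the scatter) shows that the group at this place, on an aromatic carbon meta to a large group, can by itself shift the number strongly, which the earlier step, confined to methoxy, could not show. Among these compounds, the second step, a 1.5-fold lower number from compound 1 to compound 3 (0.19 log units; within the scatter), shows that a 3-fluorophenyl ring without methoxy can match the 3-methoxy-5-(trifluoromethyl)phenyl ring, so methoxy is not the only change that separates a number like that of compound 2 from the numbers of compound 1 and compound 3. Nothing at hand bears on what lies behind either step.

As far as these compounds go, whether other groups at this place, such as a nitrile or an amine, would follow fluoro or trifluoromethyl remains open. So does what methoxy would do on a ring that carries fluoro instead of trifluoromethyl.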